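Chain Lengthening and Fluorine on the Amide Aryl

A few compounds are considered here, and "the series" means these few. Any claim that something is new, unique, unknown or untested is made for them only; others in the source may bear on it.

Compound 3 `O=C(NCCNc1nccc(-c2c(-c3cccc(F)c3)nc3sccn23)n1)c1ccccc1` gives 5060 nM in a functional assay on A-375 cells (Homo sapiens) for cytotoxicity, read by MTT assay (on this read-out higher numbers stand for weaker inhibition and lower numbers for stronger inhibition), the lowest of the three numbers. Compound 2 `O=S(=O)(NCCCNc1nccc(-c2c(-c3cccc(F)c3)nc3sccn23)n1)c1ccc(Br)cc1` gives 7040 nM in this assay, and compound 1 `O=S(=O)(NCCCNc1nccc(-c2c(-c3cccc(F)c3)nc3sccn23)n1)c1cccc(F)c1` gives 13700 nM in this assay. Compound 4 `O=C(NCCCNc1nccc(-c2c(-c3cccc(F)c3)nc3sccn23)n1)c1ccc(F)cc1` differs from compound 3 by (((4-fluorophenyl)carbonyl)amino)methyl in place of benzamido on a saturated chain carbon, two bonds along the chain from a nitrogen on an aromatic ring. Going by the values given here, no measured step changes chain length alone; the nearest are a 2.7-fold lower number from compound 1 to compound 3 (0.43 log units; beyond the scatter) and a 1.4-fold lower number from compound 2 to compound 3 (0.14 log units; within the scatter), where a shorter chain came with the amide, and a 1.9-fold lower number from compound 1 to compound 2 (0.29 log units; within the scatter), where a para substituent on the aryl ring stayed within the scatter. A step of a 1.3-fold higher number from compound 3 to compound 4 (0.11 log units; within the scatter) is therefore expected, not beyond the scatter. Compound 4 is estimated at 6500 nM, between 2500 nM and 17000 nM.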

Compound 4, half-maximal inhibitory concentration: 14900 nM
Compound 4: the middle estimate sits 2.3-fold (0.36 log units) below what was measured; the measured number falls inside the stated range.
By their numbers in this assay, from the lowest: compounds 3, 2, 1 and 4 (each within the scatter of the next, the first and the last beyond it).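

In this assay the entry of (((4-fluorophenyl)carbonyl)amino)methyl in place of benzamido at this chain carbon gives a 2.9-fold higher number from compound 3 to compound 4 (0.47 log units; beyond the scatter), so an amide at this position does not by itself keep the number low. With the carbonyl on the amine nitrogen, the comparison with the bromophenyl sulfonamide gives a 2.1-fold higher number from compound 2 to compound 4 (0.33 log units; beyond the scatter), and that with the 3-fluorophenyl sulfonamide gives a 1.1-fold higher number from compound 1 to compound 4 (0.04 log units; within the scatter). Nothing available explains these steps.

The longer chain and the fluorine enter together, and the compounds shown do not separate them. From the compounds shown here alone, how an unsubstituted benzamide on this longer chain, or an amide on a still longer chain, would read remains open.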